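Chloro for fluoro on the aryl ring across two cores

The source may report more compounds than this note shows. Statements on the series, on what has been measured and on what is new or still open speak of the compounds shown alone.

Compound 3 `O=C(COc1ccc(C(=O)/C=C/c2cccc(F)c2)cc1)N[C@H]1CCOC1=O` and compound 1 `O=C(COc1ccc(C(=O)/C=C/c2cccc(Cl)c2)cc1)N[C@H]1CCOC1=O` share one core. In a functional assay on MGC-803 cells (Homo sapiens) for antiproliferative activity, read by MTT assay, with a stated time of 72 h (on this read-out lower numbers stand for stronger inhibition and higher numbers for weaker inhibition), compound 3 stays at a limit of the assay, > 64000 nM. In this assay compound 1 gives 29100 nM. The change between them is chloro in place of fluoro on an aromatic carbon, and it brought an at least 2.1-fold lower number from compound 3 to compound 1 (0.34 log units; beyond the scatter); the step is only a bound because compound 3 sits at the limit of > 64000 nM in this assay, at which 2 of the 3 values shown sit. Compound 2 `O=C(CNc1ccc(F)cc1)N[C@H]1CCOC1=O` rests on another core; the difference between the two cores is not broken down here. In this assay compound 2 also reaches only a limit, > 64000 nM. Compound 4 `O=C(CNc1ccc(Cl)cc1)N[C@H]1CCOC1=O` carries the same kind of change, (chloro in place of fluoro on an aromatic carbon), here para to a large group rather than meta to a large group. The step expected is an at least 1.4-fold lower number from compound 2 to compound 4 (0.15 log units; that floor lies within the scatter), resting on an at least 2.1-fold lower number from compound 3 to compound 1 (0.34 log units; beyond the scatter). For compound 4 the estimate in this assay is 45000 nM, spanning 15000 nM to 130000 nM, and a limit remains likely.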

Compound 4, half-maximal inhibitory concentration: > 64000 nM
Compound 4: a limit, no number; the forecaster's own chance of this, stated with the estimate: 60%; middle value at least 1.4-fold (0.15 log units) from the limit.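

No step can be read from compound 2 to compound 4 in this assay, because each stays at a limit and gives no number: the limit of > 64000 nM in this assay, at which 3 of the 4 values shown sit.

The compounds shown leave open whether chloro in place of fluoro changes the read-out on the core of compound 2.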